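Swapping sec-butoxycarbonyl for phenylsulfonyl on a shared core

The source may hold more compounds than are shown below. What is called first, only, known or untested is meant among the compounds shown, and "the series" means these compounds.

Three compounds have been measured in a functional assay on MCF7 cells (Homo sapiens) for antiproliferative activity (on this read-out higher numbers stand for weaker inhibition and lower numbers for stronger inhibition), so far:
- compound 1 `O=C(Nc1ccc(O)c2c(=O)cc(-c3ccccc3Cl)oc12)c1ccccc1` gives 7100 nM
- compound 2 `COc1ccc(C(=O)Nc2ccc(O)c3c(=O)cc(-c4ccccc4Cl)oc23)cc1` gives 3500 nM
- compound 3 `CCC(C)OC(=O)Nc1ccc(O)c2c(=O)cc(-c3ccccc3Cl)oc12` gives 30000 nM

Compound 3 has the highest number of the three, which makes it the weakest inhibitor in this small set. Its steps to both other compounds lie beyond the usual scatter. Compound 4 `O=c1cc(-c2ccccc2Cl)oc2c(NS(=O)(=O)c3ccccc3)ccc(O)c12` has phenylsulfonyl in place of sec-butoxycarbonyl on a nitrogen on an aromatic ring.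

Within the data shown here, no measured compound carries a sulfonyl group, so no step shows this change directly. The nearest evidence comes from the two modest steps that remove an aromatic ring from the carbonyl carbon and put sec-butoxy there: a 4.2-fold higher number from compound 1 to compound 3 (0.63 log units; beyond the scatter) and an 8.6-fold higher number from compound 2 to compound 3 (0.93 log units; beyond the scatter). Compound 4 regains an aromatic ring, and its unsubstituted phenyl most resembles compound 1 (7100 nM). The methoxy step, a 2.0-fold lower number from compound 1 to compound 2 (0.31 log units; beyond the scatter), is not part of this change.

A modest move back toward stronger inhibition therefore seems likely, though the sulfonyl link makes it uncertain. The expected step is a 3.8-fold lower number from compound 3 to compound 4 (0.57 log units; beyond the scatter) in this assay (an estimate). The estimated value for compound 4 is 8000 nM (expected range 2500 nM to 30000 nM).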

Compound 4, half-maximal inhibitory concentration: 16000 nM
Compound 4: middle estimate off by 2.0-fold (0.30 log units), on the low side, and the stated range covers the measured number.
By their numbers in this assay, from the lowest: compound 2; then compound 1; then compounds 4 and 3 (each within the scatter of the next).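

In this assay, among these compounds, compound 4 is the only compound here with a sulfonyl link on this nitrogen, and it shows that an aromatic ring in the group on this nitrogen does not by itself match the two ring-bearing carbonyl compounds. Phenylsulfonyl in place of benzoyl gives a weaker result (a 2.3-fold higher number from compound 1 to compound 4 (0.35 log units; beyond the scatter)), and the gap is wider with (4-methoxyphenyl)carbonyl as the group replaced (a 4.6-fold higher number from compound 2 to compound 4 (0.66 log units; beyond the scatter)), whereas the comparison with the ring-free sec-butoxycarbonyl group cannot separate the two compounds (a 1.9-fold lower number from compound 3 to compound 4 (0.27 log units; within the scatter)). Nothing measured here explains why the sulfonyl compound falls short of the benzoyl compound, so the reason remains unknown.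

The compounds shown leave open whether the sulfonyl link responds to a methoxy group on its phenyl ring as the carbonyl link does, since compound 4 carries an unsubstituted phenyl. They also leave open whether the aromatic ring matters at all on the sulfonyl link, which a small group such as methylsulfonyl on the same nitrogen would help to show.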